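The source may report more compounds than this note shows. Statements on the series, on what has been measured and on what is new or still open speak of the compounds shown alone.

Measured compounds:
compound 1, `COC(=O)c1ccc(CN(CCCc2c(N)nc(N)nc2O)c2cc(F)c([N+](=O)[O-])cc2[N+](=O)[O-])cc1`, gives 3500 nM in a functional assay on CCRF-CEM cells (Homo sapiens) for cytotoxicity, in the presence of a further agent that is not named here; on this read-out higher numbers stand for weaker inhibition and lower numbers for stronger inhibition
compound 2, `COC(=O)c1ccc(CN(CCCc2c(N)nc(N)nc2O)c2cc(F)c(F)cc2[N+](=O)[O-])cc1`, gives 53000 nM in this assay
compound 3, `Nc1nc(N)c(CCCN(Cc2ccc(NC(CCC(=O)O)C(=O)O)cc2)c2ccc([N+](=O)[O-])c(F)c2F)c(O)n1`, gives only > 100000 nM in this assay, which is a limit of the assay and not a number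

Compounds 1 and 2 share a core and differ only in one place: nitro in place of fluoro on an aromatic carbon. This change gives a 15-fold lower number from compound 2 to compound 1 (1.18 log units; beyond the scatter). The core of compound 3 differs from that of compound 2, but the difference between the two cores is not broken down here. For compound 3 the value sits at the limit of > 100000 nM in this assay, at which 1 of the 3 values shown sits, so its position is known only as a limit.

Compound 4, `Nc1nc(N)c(CCCN(Cc2ccc(NC(CCC(=O)O)C(=O)O)cc2)c2ccc([N+](=O)[O-])c(F)c2[N+](=O)[O-])c(O)n1`, has not yet been measured in this assay. It differs from compound 3 in the same kind of change as compound 1 from compound 2: nitro in place of fluoro on an aromatic carbon. The surroundings are not identical, though: in compound 1 the entering nitro group stands para to a large group, whereas in compound 4 it stands ortho to a large group, so the change is of the same kind rather than the same.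

From this, compound 4 is expected to show an at least 6.6-fold lower number from compound 3 to compound 4 (0.82 log units; beyond the scatter), resting on the step seen from compound 2 to compound 1, a 15-fold lower number from compound 2 to compound 1 (1.18 log units; beyond the scatter), though the starting point is only a limit. For compound 4 the estimate in this assay is 15000 nM, expected to fall between 4000 nM and 80000 nM.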

Compound 4, half-maximal inhibitory concentration: 36000 nM
The estimate for compound 4 lay 2.4-fold (0.38 log units) below the measured number; low and high end bracket the measured number.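

On the core of compound 3, nitro in place of fluoro on an aromatic carbon in this assay gives an at least 2.7-fold lower number from compound 3 to compound 4 (0.44 log units; beyond the scatter), so the direction of the change seen on the core of compound 1 also appears on this second core. The size of the change cannot be said to carry over, since the two steps can only be set side by side with one of them left open: the same change on two cores in this assay, a 15-fold lower number (1.18 log units; beyond the scatter) from compound 2 to compound 1 and an at least 2.7-fold lower number (0.44 log units; beyond the scatter) from compound 3 to compound 4; the limit leaves it open whether they differ. The value of compound 3 is a limit of the assay and not a number, so the second step has only a lower bound, and two pairs of compounds do not establish a rule for the whole series: the limit of > 100000 nM in this assay, at which 1 of the 4 values shown sits.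

The compounds shown leave open how far the true value of compound 3 lies from its limit, and with it whether the change is smaller, equal or larger on this core than on the core of compound 1. They also leave open whether a nitrile or an amine on the same aromatic carbon would shift the number in the same direction, and whether the change would hold up with a longer chain in place of the present one.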